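This account rests on a few compounds, and the source may have more. Where it says the series, first, only, none or still open, it means among the compounds named here.

Working notes on the quinoline amide series.

Of the compounds shown here, two have a number so far. Compound 1, `CCN(CC)CCNc1cc(C)c2cc(NC(=O)c3ccc(Cl)c(Cl)c3)ccc2n1`, is tested in a functional assay on SK-BR-3 cells (Homo sapiens) for antiproliferative activity, read by MTT assay, with a stated time of 72 h (on this read-out lower numbers stand for stronger inhibition and higher numbers for weaker inhibition), and gives 3710 nM. Compound 2, `CCN1CCN(c2cc(C)c3cc(NC(=O)c4ccc(Cl)cc4)ccc3n2)CC1`, is tested in the same way and gives 3020 nM. The two numbers sit within the scatter of each other, so compound 2 and compound 1 are not separated by the data; compound 2 simply holds the smaller of the two figures, with compound 1 close beside it. Within the data shown here, no step between measured compounds that differ in a single place is available, so nothing is yet known about how a change at the amide end of the shared core shifts the read-out.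

Compound 3, `CCN1CCN(c2cc(C)c3cc(NC(=O)c4ccco4)ccc3n2)CC1`, is the next member to be measured. Relative to compound 2 it carries furan-2-yl in place of 4-chlorophenyl on a carbonyl carbon. Among the measured compounds shown here, with no comparable step in hand, the expectation for compound 3 is a modest move toward a higher number, around the edge of the scatter, as a 1.8-fold higher number from compound 2 to compound 3 (0.26 log units; within the scatter). Compound 3 is estimated at 5500 nM, with a range from 2000 nM to 15000 nM.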

Compound 3, half-maximal inhibitory concentration: 37500 nM
For compound 3 the middle estimate is 6.8-fold (0.83 log units) below the measured one; measured number outside the range, above it.
By their numbers in this assay, from the lowest: compounds 2 and 1 (each within the scatter of the next); then compound 3.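

Among these compounds, this is the first step that changes a single place, and it shows that the group on the carbonyl carbon of the amide is not a neutral choice. In this assay, furan-2-yl in place of 4-chlorophenyl gives a 12-fold higher number from compound 2 to compound 3 (1.09 log units; beyond the scatter), a large step that lies beyond the scatter, with the rest of the structure held constant, so inhibition at this position is sensitive to this exchange. Nothing at hand bears on the reason for this loss.

The exchange alters several things at once: the six-membered aromatic ring of carbon only gives way to a five-membered one with a hetero atom, and the chlorine leaves with it, so the compounds shown do not assign the loss to any one of these. Plain phenyl on the same carbonyl would separate the chlorine from the ring, thiophen-2-yl would test another five-membered ring, and whether any group here gives a lower number than 4-chlorophenyl remains open.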